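The source may hold more compounds than are shown below. What is called first, only, known or untested is meant among the compounds shown, and "the series" means these compounds.

Measured in a functional assay on MKN-45 cells (Homo sapiens) for inhibition, read by CCK-8 assay, with a stated time of 24 h; on this read-out higher numbers stand for weaker inhibition and lower numbers for stronger inhibition:
Compound 1 `Cc1cccc(-n2cc(-c3ccc(/C=C4\C(=O)Nc5ccccc54)cc3)nn2)c1` gives 4690 nM
Compound 2 `O=C1Nc2ccccc2/C1=C/c1ccc(-c2cn(-c3cccc(Cl)c3)nn2)cc1` gives > 20000 nM (a limit of the assay and not a number)
Compound 3 `N#Cc1ccccc1-n1cc(-c2ccc(/C=C3\C(=O)Nc4ccccc43)cc2)nn1` gives 14600 nM

Only two of these results are actual numbers, and compound 3 has the higher one, which makes it the weaker inhibitor of that pair. Its nearest neighbour on the scale is compound 1, and the gap is a 3.1-fold higher number from compound 1 to compound 3 (0.49 log units; beyond the scatter).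

Compound 4 `N#Cc1cccc(-n2cc(-c3ccc(/C=C4\C(=O)Nc5ccccc54)cc3)nn2)c1` carries 3-cyanophenyl in place of 2-cyanophenyl on an aromatic nitrogen. The atoms are the same but joined differently.

For the measured compounds named here, no measured pair makes this exact change. The nearest guides are other swaps of the group on that nitrogen, such as an at least 4.2-fold higher number from compound 1 to compound 2 (0.62 log units; beyond the scatter) alongside the modest step already given. The floor of an at least 1.3-fold lower number from compound 2 to compound 3 (0.13 log units; that floor lies within the scatter) lies within the scatter. These steps show that this group can matter, but they do not show which way moving the nitrile should go. A modest step in either direction remains possible, but no step beyond the scatter is expected.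

The expected step is a 1.3-fold lower number from compound 3 to compound 4 (0.12 log units; within the scatter).

For compound 4 the estimated value is 11000 nM, with an expected range from 4000 nM to 24000 nM.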

Compound 4, half-maximal inhibitory concentration: > 20000 nM
Compound 4 was reported as a limit; the forecaster's own chance of this, stated with the estimate: 25%; middle value at least 1.8-fold (0.25 log units) from the limit.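

Compound 4 gives a limit of the assay and not a number: the limit of > 20000 nM in this assay, at which 2 of the 4 values shown sit.

Moving the nitrile from 2-cyanophenyl to 3-cyanophenyl gives an at least 1.3-fold higher number from compound 3 to compound 4 (0.13 log units; that floor lies within the scatter), so this result alone does not show that the move matters, and the step between compound 2 and compound 4 cannot be read from two limits. Exchanging the methyl for a nitrile gives an at least 4.2-fold higher number from compound 1 to compound 4 (0.62 log units; beyond the scatter), so among 3-methylphenyl, 3-chlorophenyl and 3-cyanophenyl, only 3-methylphenyl gives a reading short of the limit.

As far as these compounds go, how far the true values of compound 2 and compound 4 lie past that limit stays unknown. Also open, from the compounds shown here alone, is whether the reading of compound 1 is special to methyl, or whether an ethyl, methoxy or amine group on that ring would give a similar reading.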